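A few compounds are considered here, and "the series" means these few. Any claim that something is new, unique, unknown or untested is made for them only; others in the source may bear on it.

Compound 1, `Nc1scc(CN2CCN(c3ccncc3)CC2)c1C(=O)c1ccc(Cl)cc1`, is one of two compounds tested in a functional assay on CHO cells with adenosine receptor A1 (Homo sapiens) as the target, read by cAMP accumulation and immunoassay, with a stated time of 6 min, tested at 0.01 uM; on this read-out higher numbers stand for a weaker effect at the one concentration tested and lower numbers for a stronger effect. In this assay compound 1 gives -4%. Compound 2, `Nc1scc(CN2CCN(c3c(F)cccc3F)CC2)c1C(=O)c1cccc(C(F)(F)F)c1`, carries different groups on both sides of the shared core; in this assay compound 2 gives 2.1%. The two numbers sit within the usual scatter of each other, so compound 1 does not stand apart from compound 2 on the numbers shown: both compounds are close to no measurable effect at the single concentration used.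

The next compound, compound 3, `Nc1scc(CN2CCN(c3cccc(Cl)c3)CC2)c1C(=O)c1ccc(Cl)cc1`, differs from compound 1 in one place: 3-chlorophenyl in place of pyridin-4-yl on an amine nitrogen in a ring. Among the measured compounds shown here, no measured pair shows a step of this kind, so the size of the step can only be expected rather than read from the data. Since compound 1 gives -4% and compound 2, with quite different groups, gives 2.1%, no step beyond the scatter in either direction is expected from compound 1 to compound 3; the expected step is a number 4 percentage points higher from compound 1 to compound 3 (within the scatter). Compound 3 is therefore estimated to give 0% in this assay, with a range from -10% to 10%.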

Compound 3, a percentage reported as activity, at one concentration (the size of the read-out at that concentration, not a potency): -3.1%
For compound 3 the middle estimate is 3.1 percentage points above the measured one; low and high end bracket the measured number.
By their numbers in this assay, from the lowest: compounds 1, 3 and 2 (each within the scatter of the next).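

The step at this position, on an amine nitrogen in a ring of the six-membered non-aromatic ring, can now be read directly: in this assay, it is a number 0.9 percentage points higher from compound 1 to compound 3 (within the scatter). The exchange replaces an aromatic ring with one hetero atom and one hydrogen-bond acceptor by a carbon-only aromatic ring bearing chlorine, yet the read-out stays within the scatter, so at the single concentration used this position tolerates the change without a visible shift. No measured evidence is available to explain this outcome.

The compounds shown leave open whether any group on this nitrogen can move the read-out beyond the scatter, for instance a longer alkyl chain or a phenyl ring bearing a carboxylic acid in place of the 3-chlorophenyl. They also leave open whether compound 1 and compound 3 would remain indistinguishable at other concentrations, since a read-out at one concentration is not a potency.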